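The source may report more compounds than this note shows. Statements on the series, on what has been measured and on what is new or still open speak of the compounds shown alone.

Among the compounds with values here, compound 1 `CC1=CC[C@@H]([C@@](C)(O)CCCC(C)(C)NC(=S)N/N=C\c2ccccc2)CC1` stands second highest of the three numbers so far in a functional assay on PCO3 cells (Homo sapiens) for cytotoxicity, read by sulforhodamine B assay (on this read-out higher numbers stand for weaker inhibition of growth and lower numbers for stronger inhibition of growth), where compound 1 gives 8470 nM. Compound 2 `COc1ccc(/C=N\NC(=S)NC(C)(C)CCC[C@](C)(O)[C@@H]2CC=C(C)CC2)cc1` gives 7660 nM, and a 1.1-fold lower number from compound 1 to compound 2 (0.04 log units; within the scatter). Compound 3 `CC1=CC[C@@H]([C@@](C)(O)CCCC(C)(C)NC(=S)N/N=C\c2ccccc2[N+](=O)[O-])CC1` gives 39900 nM; a 4.7-fold higher number from compound 1 to compound 3 (0.67 log units; beyond the scatter), and a 5.2-fold higher number from compound 2 to compound 3 (0.72 log units; beyond the scatter). Compound 4 `CC1=CC[C@@H]([C@@](C)(O)CCCC(C)(C)NC(=S)N/N=C\c2ccc(Cl)cc2)CC1` differs from compound 1 in one way: chloro in place of hydrogen on an aromatic carbon. Within the data shown here, two measured steps bear on this, both changes on the same ring: the methoxy step stayed within the scatter, the nitro step was modest. The new group sits para to a large group, as the methoxy did, so an expected step that stays within the scatter in this assay is a 1.1-fold lower number from compound 1 to compound 4 (0.02 log units; within the scatter). Compound 4 is therefore estimated at 8000 nM, somewhere between 3500 nM and 18000 nM.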

Compound 4, concentration for 50% growth inhibition: 7580 nM
For compound 4 the middle estimate is 1.1-fold (0.02 log units) above the measured one; low and high end bracket the measured number.
By their numbers in this assay, from the lowest: compounds 4, 2 and 1 (each within the scatter of the next); then compound 3.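

In this assay, chloro on the aromatic carbon para to a large group gives a 1.1-fold lower number from compound 1 to compound 4 (0.05 log units; within the scatter) and a 1.0-fold lower number from compound 2 to compound 4 (0.00 log units; within the scatter), so hydrogen, methoxy and chloro at this place cannot be told apart. Compound 3 goes against this flat picture, with a 5.3-fold lower number from compound 3 to compound 4 (0.72 log units; beyond the scatter), but its 2-nitrophenyl differs from 4-chlorophenyl in both the group and its place on the ring. Nothing available explains these steps. Going by these compounds, whether the gap follows the nitro group or its place stays open. So does whether an amine or a carboxylic acid para to a large group would also stay within the scatter.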